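Pyridin-2-yl for 4-nitrophenyl on the ring amine nitrogen

The compounds below may be only part of what the source reports. "The series", "measured", "known", "first", "only" and "open" are said of these compounds alone.

Within the data shown here, compound 3 `O=[N+]([O-])c1ccc(N2CCN(Cn3nc(-c4ccc5c(c4)OCCO5)oc3=S)CC2)cc1` gives 29500 nM in a functional assay on HepG2 cells (Homo sapiens) for antiproliferative activity, read by MTT assay, with a stated time of 48 h (on this read-out lower numbers stand for stronger inhibition and higher numbers for weaker inhibition), and is the only member with a number. Compound 1 `S=c1oc(-c2ccc3c(c2)OCCO3)nn1CN1CCN(c2cccc(Cl)c2Cl)CC1` sits at the limit > 50000 nM in this assay. Compound 2 `S=c1oc(-c2ccc3c(c2)OCCO3)nn1CN1CCN(c2ccc(Cl)cc2)CC1` likewise sits at the limit > 50000 nM in this assay. Hence a step that the two limits leave unreadable from compound 1 to compound 2, while an at least 1.6-fold lower number from compound 1 to compound 3 (0.22 log units; that floor lies within the scatter) and an at least 1.6-fold lower number from compound 2 to compound 3 (0.22 log units; that floor lies within the scatter) give only floors inside the scatter. Compound 4 `S=c1oc(-c2ccc3c(c2)OCCO3)nn1CN1CCN(c2ccccn2)CC1` differs from compound 3 by pyridin-2-yl in place of 4-nitrophenyl on an amine nitrogen in a ring. Among the measured compounds shown here, no measured step exchanges the nitro-bearing ring for a heteroaryl, so the bearing steps are those two floors; with the limit of > 50000 nM in this assay, at which 2 of the 3 values shown sit, near, a return toward the limit is as plausible as staying level. Compound 4 is estimated at 40000 nM, with a range of 15000 nM to 100000 nM. The expected step is a 1.4-fold higher number from compound 3 to compound 4 (0.13 log units; within the scatter).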

Compound 4, half-maximal inhibitory concentration: 11400 nM
Estimate against measurement, compound 4: 3.5-fold (0.55 log units) above; measured number outside the range, below it.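

In this assay, among these compounds, pyridin-2-yl in place of 4-nitrophenyl on the ring amine nitrogen gives a 2.6-fold lower number from compound 3 to compound 4 (0.41 log units; beyond the scatter), the only step at this position with a size that can be read and that lies beyond the scatter. Against the chlorinated members, the same group gives an at least 4.3-fold lower number from compound 2 to compound 4 (0.64 log units; beyond the scatter) and an at least 4.3-fold lower number from compound 1 to compound 4 (0.64 log units; beyond the scatter), whereas the earlier floors lay within the scatter. These two steps are floors and not sizes: the limit of > 50000 nM in this assay, at which 2 of the 4 values shown sit.

Whether the ring nitrogen of pyridin-2-yl accounts for the lower number remains open. Plain phenyl or pyridin-4-yl at this position would separate that nitrogen from the loss of the chloro and nitro groups.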